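Lengthening a hydroxyalkyl chain on an amine nitrogen

The source may report more compounds than this note shows. Statements on the series, on what has been measured and on what is new or still open speak of the compounds shown alone.

Measured so far:
- compound 1, `COc1cc(/C=C/C(=O)/C=C(/C=C/c2ccc(O)c(OC)c2)NCCO)ccc1O`: 90.9%
- compound 2, `COc1cc(/C=C/C2=CC(=O)CC(c3ccc(O)c(OC)c3)N2CCCO)ccc1O`: 80.3%

Of the compounds shown here, two have been measured in an ADME assay on CHO-K1 cells (Cricetulus griseus) for activation, read by fluorescence, tested at 10 uM; a lower number here means a stronger effect, a higher number a weaker effect of the compound at the concentration tested. Compound 1 gives 90.9%, which is the higher of the two numbers and so the weaker effect at the concentration tested. Compound 2 gives 80.3%, a number that lies lower by an amount beyond the usual scatter; these two compounds differ in more than one place, so nothing can be said about any single change between them.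

Compound 3, `COc1cc(/C=C/C(=O)/C=C(/C=C/c2ccc(O)c(OC)c2)NCCCO)ccc1O`, is not yet measured. It differs from compound 1 in a single place: hydroxymethyl in place of hydroxy on a saturated chain carbon, two bonds along the chain from an amine nitrogen. The chain carrying the hydroxy group on the amine nitrogen grows by one carbon while the shared core stays the same.

Among the compounds with values here, no step between measured compounds that differ in one place is available, so the size of this change in this assay is open. The change adds a single carbon to a side chain. The expected step is small and within the scatter, going slightly toward a lower number. The expected step for compound 3 is a number 2.9 percentage points lower from compound 1 to compound 3 (within the scatter). Compound 3 is therefore estimated at 88%, with a range from 74% to 100%.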

Compound 3, a percentage reported as activity, at one concentration (the size of the read-out at that concentration, not a potency): 89.9%
For compound 3 the middle estimate is 1.9 percentage points below the measured one; low and high end bracket the measured number.
By their numbers in this assay, from the lowest: compounds 2, 3 and 1 (each within the scatter of the next, the first and the last beyond it).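

Within the data shown here, this is the first step that changes only one place, and it gives the chain on the amine nitrogen a direct reading. In this assay, replacing (2-hydroxyethyl)amino with (3-hydroxypropyl)amino on the shared core gives a number 1 percentage points lower from compound 1 to compound 3 (within the scatter), so the two compounds cannot be told apart in this read-out and this lengthening of the chain has no effect that repeated measurements could separate from scatter. Nothing available here explains this result, and a single pair offers no basis for a cause.

The compounds shown leave open whether the chain tolerates larger departures, such as a longer chain like 4-hydroxybutyl, or an amine or a carboxylic acid in place of the hydroxy group. Also open, going by these compounds, is whether the same lengthening would read the same way on a different core, since this one step describes only the core of compound 1 and cannot be extended to other compounds.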